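A larger alkyl group on the piperidine sulfonamide

The source may report more compounds than this note shows. Statements on the series, on what has been measured and on what is new or still open speak of the compounds shown alone.

Measured so far:
compound 1 `O=C(Nc1ccc(S(=O)(=O)N2CCNCC2)cc1)c1ccc([N+](=O)[O-])o1` with 26400 nM
compound 2 `CC1(C)CCN(S(=O)(=O)c2ccc(NC(=O)c3ccc([N+](=O)[O-])o3)cc2)CC1` with 600 nM

Among the measured compounds shown here, in an assay on CHO-K1 cells for activation of DNA damage-inducible transcript 3 protein (Homo sapiens), read by a luciferase reporter (on this read-out higher numbers stand for an effect only at larger amounts of compound and lower numbers for an effect already at smaller amounts), compound 2 holds the lower of the two numbers measured so far. For the measured compounds named here, the single measured step, a 44-fold lower number from compound 1 to compound 2 (1.64 log units; beyond the scatter), is large and beyond the scatter, and it arose from putting 4,4-dimethylpiperidin-1-yl in place of piperazin-1-yl on the sulfonyl sulfur.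

Compound 3 `CC(C)(C)C1CCN(S(=O)(=O)c2ccc(NC(=O)c3ccc([N+](=O)[O-])o3)cc2)CC1` is the next compound, differing from compound 2 by 4-(tert-butyl)piperidin-1-yl in place of 4,4-dimethylpiperidin-1-yl on a sulfonyl sulfur. Going by the values given here, no measured step touches this kind of change: the one step known concerns the exchange of the ring itself, not the size of the alkyl group on it, so it offers no direct guide. With both groups carrying no donors or acceptors and the same ring, the step is expected to be no change at the digits printed from compound 2 to compound 3 (within the scatter), that is, nothing beyond the scatter in this assay. Compound 3 is therefore estimated at 600 nM, with a range from 150 nM to 2400 nM.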

Compound 3, concentration for half-maximal activity: 700 nM
Compound 3: middle estimate off by 1.2-fold (0.07 log units), on the low side, within the range that was stated.
By their numbers in this assay, from the lowest: compounds 2 and 3 (each within the scatter of the next); then compound 1.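

With 4-(tert-butyl)piperidin-1-yl in place of 4,4-dimethylpiperidin-1-yl on the sulfonyl sulfur, this assay gave a 1.2-fold higher number from compound 2 to compound 3 (0.07 log units; within the scatter) and so showed that this change in the alkyl group on the piperidine makes no difference beyond the scatter. Putting 4-(tert-butyl)piperidin-1-yl in place of piperazin-1-yl gave a 38-fold lower number from compound 1 to compound 3 (1.58 log units; beyond the scatter) and so showed that the large step from piperazin-1-yl is not confined to 4,4-dimethylpiperidin-1-yl. No evidence is at hand to explain either step.

The compounds shown leave open how an unsubstituted piperidin-1-yl, a morpholin-4-yl or a piperidine bearing a carboxylic acid would stand on the sulfonyl sulfur. They also cannot separate the effect of the ring nitrogen in piperazin-1-yl from that of the alkyl groups on the piperidines.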